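Cytotoxicity in HEL cells: swapping the aryl group on the ether

The source may report more compounds than this note shows. Statements on the series, on what has been measured and on what is new or still open speak of the compounds shown alone.

Compound 1 `CCC1(Cc2ccccc2)OS(=O)(=O)C=C1OCc1ccc(Cl)c(Cl)c1`: 36700 nM
Compound 2 `CCC1(Cc2ccccc2)OS(=O)(=O)C=C1OC`: > 200000 nM

Among the measured compounds shown here, in an ADME assay on HEL cells (Homo sapiens) for cytotoxicity, with a stated time of 3 days (a higher number here means that more compound is tolerated, a lower number that less compound is tolerated), compound 1 is the only compound with a number. For compound 2 the result is a limit of the assay, > 200000 nM. Going from compound 1 to compound 2, an at least 5.4-fold higher number from compound 1 to compound 2 (0.73 log units; beyond the scatter), with the limit of > 200000 nM in this assay, at which 1 of the 2 values shown sits.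

Compound 3 `CCC1(Cc2ccccc2)OS(=O)(=O)C=C1OCCCc1ccccc1` differs from compound 1 by phenethyl in place of 3,4-dichlorophenyl on a saturated chain carbon bound to an oxygen on an unsaturated carbon. No measured step covers an aryl-for-aryl swap; the only step shown removes the aryl group altogether. A step within the scatter or a modest rise is expected. For compound 3 the estimate is 55000 nM, between 18000 nM and 160000 nM, which would mean a 1.5-fold higher number from compound 1 to compound 3 (0.18 log units; within the scatter).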

Compound 3, half-maximal cytotoxic concentration: 133000 nM
Compound 3: the middle estimate sits 2.4-fold (0.38 log units) below what was measured; measured number inside the range.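

Both groups carry one six-membered aromatic ring of carbon only, yet in this assay phenethyl in place of 3,4-dichlorophenyl on a saturated chain carbon bound to an oxygen on an unsaturated carbon gives a 3.6-fold higher number from compound 1 to compound 3 (0.56 log units; beyond the scatter). Keeping such a ring at this place therefore does not hold the number at the level of compound 1. In this assay phenethyl in place of hydrogen on a saturated chain carbon bound to an oxygen on an unsaturated carbon gives an at least 1.5-fold lower number from compound 2 to compound 3 (0.17 log units; that floor lies within the scatter). This step is only a floor because compound 2 stands at a limit: the limit of > 200000 nM in this assay, at which 1 of the 3 values shown sits.

Whether the two chlorines or the longer link accounts for the step stays open. So does the outcome with an amine or a carboxylic acid at this place.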